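Notes on one substituent series at a single aromatic carbon

The compounds below may be only part of what the source reports. "The series", "measured", "known", "first", "only" and "open" are said of these compounds alone.

Values in a functional assay on BeWo cells (Homo sapiens) for cytotoxicity, read by MTT assay, with a stated time of 72 h; on this read-out higher numbers stand for weaker inhibition and lower numbers for stronger inhibition:
compound 1 `Cc1nnc2nnc(N3CCCC3)nn12` gives 5360 nM
compound 2 `CC(C)(C)c1nnc2nnc(N3CCCC3)nn12` gives 12500 nM
compound 3 `C1CCC(c2nnc3nnc(N4CCCC4)nn23)CC1` gives 22000 nM

Compound 3 holds the highest number of the three. Its gap to compound 2 lies within the scatter, and its gap to compound 1 lies beyond it, as the step of a 4.1-fold higher number from compound 1 to compound 3 (0.61 log units; beyond the scatter) shows. The step of a 2.3-fold higher number from compound 1 to compound 2 (0.37 log units; beyond the scatter) also runs upward and is modest, while a 1.8-fold higher number from compound 2 to compound 3 (0.25 log units; within the scatter) stays within the scatter.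

The next compound, compound 4 `CCCCCc1nnc2nnc(N3CCCC3)nn12`, differs from compound 3 by pentyl in place of cyclohexyl on an aromatic carbon. The two measured steps that start at compound 1 bear on this change: each puts a larger group in place of methyl on the same aromatic carbon, and each raises the number modestly. Pentyl is a chain without a ring, whereas cyclohexyl carries one; no measured step exchanges a ring for a chain, so the direction of this step cannot be read from the series. For compound 4 the expectation in this assay is a step of a 1.5-fold lower number from compound 3 to compound 4 (0.17 log units; within the scatter) that stays within the scatter. Compound 4 is therefore estimated at 15000 nM, with a range from 6000 nM to 35000 nM.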

Compound 4, half-maximal inhibitory concentration: 27900 nM
The estimate for compound 4 lay 1.9-fold (0.27 log units) below the measured number; the range from low to high includes it.
By their numbers in this assay, from the lowest: compound 1; then compounds 2, 3 and 4 (each within the scatter of the next, the first and the last beyond it).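

In this assay the exchange of a ring for a chain on this aromatic carbon gives a 1.3-fold higher number from compound 3 to compound 4 (0.10 log units; within the scatter) and so does not separate pentyl from cyclohexyl, which means the ring adds no readable difference here. Pentyl does separate from tert-butyl, with a 2.2-fold higher number from compound 2 to compound 4 (0.35 log units; beyond the scatter) as the step, and the step from methyl to pentyl is the widest in the series at a 5.2-fold higher number from compound 1 to compound 4 (0.72 log units; beyond the scatter) and leaves all three larger groups beyond the scatter from methyl, with compound 1 holding the lowest number of the four. No measurement on hand accounts for these steps.

Every group shown at this carbon is a plain hydrocarbon of methyl size or larger, so it remains open whether hydrogen, an amine or a carboxylic acid in this place would keep the number near that of compound 1 or move it elsewhere. As far as these compounds go, a chain longer than pentyl is also open, as is any change to the other substituent on the shared core, since that part stays the same across all four compounds.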